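Replacing 4-(dimethylamino)phenyl with 3-chlorophenyl in a thiocarbonyl series

This account rests on a few compounds, and the source may have more. Where it says the series, first, only, none or still open, it means among the compounds named here.

Of the compounds shown here, three sharing one core have been read in a functional assay on NCI/ADR cells (Homo sapiens) for cytotoxicity, read by sulforhodamine B assay; a higher number here means a weaker inhibitor of growth, a lower number a stronger inhibitor of growth. Compound 1 `CC1=CC[C@@H]([C@@](C)(O)CCCC(C)(C)NC=S)CC1` gives > 100000 nM, which is a limit of the assay. Compound 2 `CC1=CC[C@@H]([C@@](C)(O)CCCC(C)(C)NC(=S)N/N=C\c2ccccc2)CC1` gives a true number, 23800 nM. Compound 3 `CC1=CC[C@@H]([C@@](C)(O)CCCC(C)(C)NC(=S)N/N=C\c2ccc(N(C)C)cc2)CC1` gives > 100000 nM, again a limit and not a number. Compound 3 thus sits at the limit of > 100000 nM in this assay, at which 2 of the 3 values shown sit.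

Compound 4 `CC1=CC[C@@H]([C@@](C)(O)CCCC(C)(C)NC(=S)N/N=C\c2cccc(Cl)c2)CC1` differs from compound 3 in one place: 3-chlorophenyl in place of 4-(dimethylamino)phenyl on a carbon with a double bond to nitrogen. In words, 3-chlorophenyl stands in place of 4-(dimethylamino)phenyl on a carbon with a double bond to nitrogen.

Within the data shown here, two measured steps bear on this change. The first, which adds the group carrying the aromatic ring, is an at least 4.2-fold lower number from compound 1 to compound 2 (0.62 log units; beyond the scatter). The second, dimethylamino in place of hydrogen on an aromatic carbon, is an at least 4.2-fold higher number from compound 2 to compound 3 (0.62 log units; beyond the scatter). Compound 4 keeps the aromatic ring but lacks the dimethylamino group, so its reading is expected to fall near that of compound 2 at 23800 nM. Among the measured compounds shown here, no chlorine-bearing compound has been measured, which leaves the range wide. The expected change in this assay is an at least 5.0-fold lower number from compound 3 to compound 4 (0.69 log units; beyond the scatter), a step toward a lower number and beyond the scatter. For compound 4 the estimate is 20000 nM, with an expected range from 6000 nM to 70000 nM.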

Compound 4, concentration for total growth inhibition: 31900 nM
Estimate against measurement, compound 4: 1.6-fold (0.20 log units) below, and the stated range covers the measured number.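

In this assay, 3-chlorophenyl in place of 4-(dimethylamino)phenyl on a carbon with a double bond to nitrogen gives an at least 3.1-fold lower number from compound 3 to compound 4 (0.49 log units; beyond the scatter), returning the series to a true reading. Compound 3 stands only at a limit of the assay, so the size of that step is a lower bound: the limit of > 100000 nM in this assay, at which 2 of the 4 values shown sit. Chloro in place of hydrogen on an aromatic carbon gives a 1.3-fold higher number from compound 2 to compound 4 (0.13 log units; within the scatter), so these two readings cannot be told apart, and among the compounds shown that carry the aromatic ring, only the one with dimethylamino sits at the limit.

The change from compound 3 to compound 4 swaps the group and its place on the ring together, so the compounds shown leave open whether the dimethylamino group itself or its place sets the limit reading, a question that 3-(dimethylamino)phenyl or 4-chlorophenyl would address. Among these compounds, they also leave open how other groups on this ring, such as a methoxy, a primary amine or a carboxylic acid, would read, since chloro is the only one that gives a number here alongside the unsubstituted ring.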